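Swapping a pyrazole ring for a small amide at one carbon

The compounds below may be only part of what the source reports. "The series", "measured", "known", "first", "only" and "open" are said of these compounds alone.

Measured so far:
Compound 1 `Cc1[nH]ncc1-c1cncc(-c2ccc(C(N)=O)c(OC(C)C)c2)c1`: 320 nM
Compound 2 `CC(C)Oc1cc(-c2cncc(-c3cnn(C)c3)c2)ccc1C(N)=O`: 750 nM

Both compounds were tested in an assay on HeLa cells for inhibition of MAP kinase-interacting serine/threonine-protein kinase 1/2 (Homo sapiens), read by AlphaScreen, with a stated time of 2 h; on this read-out higher numbers stand for weaker inhibition and lower numbers for stronger inhibition. Within the data shown here, compound 2 stands at the higher of the two numbers; the only other compound, compound 1, sits at 320 nM, and the step of a 2.3-fold higher number from compound 1 to compound 2 (0.37 log units; beyond the scatter) was modest but beyond the scatter.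

Compound 3 `CNC(=O)c1cncc(-c2ccc(C(N)=O)c(OC(C)C)c2)c1` has not yet been measured. Its structural change from compound 2 is methylcarbamoyl in place of 1-methyl-1H-pyrazol-4-yl on an aromatic carbon. Among the measured compounds shown here, the single measured step, from compound 1 to compound 2, altered the same 1-methyl-1H-pyrazol-4-yl group that now leaves, and it shifted the number only modestly. For the measured compounds named here, no measured step shows what happens when that ring is replaced by methylcarbamoyl, so the outcome is open. Compound 3 is expected to give a weaker result, an estimate of 1500 nM with a range of 400 nM to 6000 nM. This estimate corresponds to a step of a 2.0-fold higher number from compound 2 to compound 3 (0.30 log units; within the scatter) in this assay.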

Compound 3, half-maximal inhibitory concentration: 1900 nM
For compound 3 the middle estimate is 1.3-fold (0.10 log units) below the measured one; the range from low to high includes it.
By their numbers in this assay, from the lowest: compound 1; then compound 2; then compound 3.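

In this assay, replacing the 1-methyl-1H-pyrazol-4-yl ring with the open methylcarbamoyl group gives a 2.5-fold higher number from compound 2 to compound 3 (0.40 log units; beyond the scatter), the first sign of what happens when this carbon carries no ring at all. Measured against the 5-methyl-1H-pyrazol-4-yl group, the same amide gives a 5.9-fold higher number from compound 1 to compound 3 (0.77 log units; beyond the scatter), so among these three compounds both pyrazoles give lower numbers than the amide, yet inhibition is still measurable without a ring at this position. No evidence is available to explain why the amide gives the higher number.

Going by these compounds, it remains open whether the loss of the ring or the nature of the amide matters more. An amine or a carboxylic acid at this carbon, or a longer chain in place of the amide's methyl, could help separate these two possibilities.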